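Bromine on the Phenyl Ring: Expecting No Change

A few compounds are considered here, and "the series" means these few. Any claim that something is new, unique, unknown or untested is made for them only; others in the source may bear on it.

Two measured compounds share one core and differ only in the amine at the end of the chain attached to an oxygen on an aromatic ring. Compound 1 `COc1cc2c(Oc3ccc(NC(=O)c4nn(-c5ccccc5)c(=O)c5ccccc45)cc3F)ccnc2cc1OCCCN1CCCC1` carries a pyrrolidin-1-yl group there, and in a functional assay on NCI-H460 cells (Homo sapiens) for cytotoxicity, read by MTT assay, with a stated time of 72 h (a higher number here means a weaker inhibitor, a lower number a stronger inhibitor), compound 1 gives 480 nM. Compound 2 `COc1cc2c(Oc3ccc(NC(=O)c4nn(-c5ccccc5)c(=O)c5ccccc45)cc3F)ccnc2cc1OCCCN1CCC(C)CC1` carries a 4-methylpiperidin-1-yl group instead, and in this assay compound 2 gives 550 nM. That exchange, a 1.1-fold higher number from compound 1 to compound 2 (0.06 log units; within the scatter), leaves the two within the scatter, so compound 2 has the higher of the two numbers but cannot be separated from compound 1.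

Compound 3 `COc1cc2c(Oc3ccc(NC(=O)c4nn(-c5ccc(Br)cc5)c(=O)c5ccccc45)cc3F)ccnc2cc1OCCCN1CCC(C)CC1` keeps the 4-methylpiperidin-1-yl group and changes the far end of the molecule: bromo in place of hydrogen on an aromatic carbon, the phenyl becoming 4-bromophenyl. Among the compounds with values here, no measured step touches this ring, so nothing among the measured compounds speaks for or against a shift, and no step beyond the scatter is expected. The estimate for compound 3 is 550 nM, with a range from 200 nM to 1500 nM, meaning an expected step of no change at the digits printed from compound 2 to compound 3 (within the scatter).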

Compound 3, half-maximal inhibitory concentration: 350 nM
Compound 3: the middle estimate sits 1.6-fold (0.20 log units) above what was measured; low and high end bracket the measured number.
By their numbers in this assay, from the lowest: compounds 3, 1 and 2 (each within the scatter of the next).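

The phenyl ring at the far end of the molecule now has a measured step of its own: in this assay, bromo in place of hydrogen on an aromatic carbon, para to a large group, gives a 1.6-fold lower number from compound 2 to compound 3 (0.20 log units; within the scatter). The earlier pair varied only the amine at the end of the chain, whereas this step shows that one bromine atom on this ring leaves compound 3 inseparable from compound 2. No outside measurement bears on this step, so the data offer no explanation for it.

From the compounds shown here alone, whether chlorine, a methoxy group or an amine on the same carbon would also stay within the scatter remains open, as does the effect of bromo on other carbons of this ring. Also open, going by these compounds, is whether the bromo exchange would give a similar step with the pyrrolidin-1-yl group of compound 1 at the end of the chain.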